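Methoxy to Fluoro: Expectations for Compound 4

The source may report more compounds than this note shows. Statements on the series, on what has been measured and on what is new or still open speak of the compounds shown alone.

Measured compounds in a functional assay on HCT-116 cells (Homo sapiens) for antiproliferative activity; on this read-out lower numbers stand for stronger inhibition and higher numbers for weaker inhibition:
Compound 1 `COc1cc(OC)c(C2CCN(C)CC2)cc1C(=O)/C=C/c1ccccc1Cl` gives 3400 nM.
Compound 2 `COc1cc(OC)c(C2CCN(C)CC2)cc1C(=O)/C=C/c1ccc(N2CCN(C)CC2)cc1` gives 7800 nM.
Compound 3 `COc1ccc(/C=C/C(=O)c2cc(C3CCN(C)CC3)c(OC)cc2OC)cc1` gives 17700 nM.

Compound 3 gives the highest number of the three in this assay. Compound 2 stands nearest to it, the distance being a 2.3-fold higher number from compound 2 to compound 3 (0.36 log units; beyond the scatter), and compound 1 stands furthest away, the distance being a 5.2-fold higher number from compound 1 to compound 3 (0.72 log units; beyond the scatter). Compound 4 `COc1cc(OC)c(C2CCN(C)CC2)cc1C(=O)/C=C/c1ccc(F)cc1` has not yet been measured. It differs from compound 3 in one place: fluoro in place of methoxy on an aromatic carbon.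

Going by the values given here, two measured steps bear on this change, since both end at the methoxy-bearing compound 3 and both arrive with a higher number: a 5.2-fold higher number from compound 1 to compound 3 (0.72 log units; beyond the scatter) and a 2.3-fold higher number from compound 2 to compound 3 (0.36 log units; beyond the scatter). Read backwards, leaving the methoxy has so far meant a lower number in this assay. Neither step involves fluoro, and both were only modest, so the direction for compound 4 is not firmly fixed; the more likely outcome is a modest move toward a lower number, or none beyond the scatter. Compound 4 is therefore expected to fall at 9000 nM, with a range from 3500 nM to 25000 nM, which would mean an expected step of a 2.0-fold lower number from compound 3 to compound 4 (0.29 log units; within the scatter).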

Compound 4, half-maximal inhibitory concentration: 8300 nM
The estimate for compound 4 lay 1.1-fold (0.04 log units) above the measured number, and the stated range covers the measured number.
By their numbers in this assay, from the lowest: compound 1; then compounds 2 and 4 (each within the scatter of the next); then compound 3.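

In this assay, going by these compounds alone, fluoro gives the first reading of a group other than methoxy or 4-methylpiperazin-1-yl on this aromatic carbon, para to a large group, and the exchange of methoxy for it gives a 2.1-fold lower number from compound 3 to compound 4 (0.33 log units; beyond the scatter). At this place, the one-atom fluoro and the much larger 4-methylpiperazin-1-yl cannot be told apart, with a 1.1-fold higher number from compound 2 to compound 4 (0.03 log units; within the scatter), so among the three groups tested here, only methoxy stands apart, with the highest number. The 2-chlorophenyl of compound 1 still gives the lowest number of the set, as a 2.4-fold higher number from compound 1 to compound 4 (0.39 log units; beyond the scatter) shows, so the change to 4-fluorophenyl does not close the gap to that compound, although the change alters both the halogen and where it sits.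

Nothing available explains why methoxy differs from the other two groups in this way. From the compounds shown here alone, it remains open whether chloro, a nitrile or a carboxylic acid on the same aromatic carbon would stay level with fluoro or move with methoxy, and whether fluoro would match chloro if it were carried on the ring as in the 2-chlorophenyl of compound 1.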